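The compounds below may be only part of what the source reports. "The series", "measured", "known", "first", "only" and "open" are said of these compounds alone.

Of the compounds shown here, three have been measured in a functional assay for inhibition, with Rattus norvegicus as the target, at pH 7.35; on this read-out lower numbers stand for stronger inhibition and higher numbers for weaker inhibition. Compound 1 (`CCC(NC(=O)C(CC(C)C)NC(=O)OCc1ccccc1)C(=O)C(=O)OC`) gives 280000 nM, the highest number of the set and so the weakest inhibition, and its gaps to the other two lie beyond the usual scatter. Compound 2 (`CCOC(=O)C(=O)C(CC)NC(=O)C(CC(C)C)NC(=O)CCc1ccccc1`) gives 20000 nM, and compound 3 (`CCOC(=O)C(=O)[C@H](CC)NC(=O)[C@H](CC(C)C)NC(=O)[C@H](CC(C)C)NS(=O)(=O)c1ccc2ccccc2c1`) gives 100000 nM. These three differ from one another in more than one place, so no single change can be read from them.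

The next compound, compound 4 (`CCCCNC(=O)C(=O)C(CC)NC(=O)C(CC(C)C)NC(=O)OCc1ccccc1`), has butylamino in place of methoxy on a carbonyl carbon of compound 1: butylamino in place of methoxy on a carbonyl carbon. Going by the values given here, no measured pair shows this change, which leaves the expectation loose. It rests only on compound 1 sitting at the top of the range, with compound 2 at 20000 nM well lower. A moderate move toward stronger inhibition in this assay is therefore expected, though no change beyond the scatter remains possible. The expected step is a 4.7-fold lower number from compound 1 to compound 4 (0.67 log units; beyond the scatter). Compound 4 is estimated at 60000 nM, within an expected range of 10000 nM to 300000 nM.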

Compound 4, half-maximal inhibitory concentration: 35000 nM
For compound 4 the middle estimate is 1.7-fold (0.23 log units) above the measured one; measured number inside the range.
By their numbers in this assay, from the lowest: compounds 2 and 4 (each within the scatter of the next); then compound 3; then compound 1.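

In this assay, going by these compounds alone, butylamino in place of methoxy on a carbonyl carbon gives an 8.0-fold lower number from compound 1 to compound 4 (0.90 log units; beyond the scatter), the first single change that can be read in this set. It shows that this position responds to what it carries: going from methoxycarbonyl to butylcarbamoyl strengthens inhibition beyond the scatter, but the longer chain and the added hydrogen-bond donor arrive together, and this one step cannot tell them apart. Nothing at hand gives a measured reason for the step.

Going by these compounds, it remains open whether a methylamino group, which carries the nitrogen with only a short chain, would give a similar step, or whether a longer chain such as hexylamino would go further. On these data alone, it is also open whether butylamino would act in the same way on the cores of compound 2 and compound 3.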